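A 2-(hydroxymethyl)pyrrolidin-1-yl group replaces dimethylamino in compound 4

The source may report more compounds than this note shows. Statements on the series, on what has been measured and on what is new or still open speak of the compounds shown alone.

The measured set holds compound 1 `CCOC(=O)N1CCN(/[N+]([O-])=N/Oc2cc(O/N=[N+](\[O-])N(C)C)c([N+](=O)[O-])cc2[N+](=O)[O-])CC1`, compound 2 `CC1CCCCN1/[N+]([O-])=N/Oc1cc(O/N=[N+](\[O-])N(C)C)c([N+](=O)[O-])cc1[N+](=O)[O-]` and compound 3 `CCN(CC)/[N+]([O-])=N/Oc1cc(O/N=[N+](\[O-])N(C)C)c([N+](=O)[O-])cc1[N+](=O)[O-]`. In a functional assay on HL-60 cells (Homo sapiens) for antiproliferative activity, read by MTT assay, with a stated time of 72 h (on this read-out higher numbers stand for weaker inhibition of growth and lower numbers for stronger inhibition of growth), compound 1 gives 2000 nM, compound 2 gives 4900 nM and compound 3 gives 2300 nM. Compound 3 thus stands second highest of the three numbers; the step of a 1.2-fold higher number from compound 1 to compound 3 (0.06 log units; within the scatter) lies within the scatter, whereas a 2.1-fold lower number from compound 2 to compound 3 (0.33 log units; beyond the scatter) and a 2.5-fold higher number from compound 1 to compound 2 (0.39 log units; beyond the scatter) are modest steps beyond it.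

Compound 4 `CCN(CC)/[N+]([O-])=N/Oc1cc(O/N=[N+](\[O-])N2CCCC2CO)c([N+](=O)[O-])cc1[N+](=O)[O-]` differs from compound 3 in one place: 2-(hydroxymethyl)pyrrolidin-1-yl in place of dimethylamino on a double-bonded nitrogen. Going by the values given here, every measured step in this set exchanges the amine on the other double-bonded nitrogen; no measured step touches the dimethylamino group that is exchanged here, so none bears directly on this change. The measured steps were at most modest, and the shared core is unchanged, so the writer expects for compound 4 in this assay a step of no change at the digits printed from compound 3 to compound 4 (within the scatter), in effect none beyond the scatter, with the wide range reflecting the absence of a precedent. The estimate for compound 4 is 2300 nM, between 800 nM and 7000 nM.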

Compound 4, concentration for total growth inhibition: 4000 nM
Beside the measured number, compound 4's estimate is 1.7-fold (0.24 log units) below it; the range from low to high includes it.
By their numbers in this assay, from the lowest: compounds 1, 3, 4 and 2 (each within the scatter of the next, the first and the last beyond it).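

Going by these compounds alone, compound 4 is the first compound here in which the dimethylamino group is exchanged on this double-bonded nitrogen, whose other neighbours are a double-bonded nitrogen and an oxygen, and in this assay the change gives a 1.7-fold higher number from compound 3 to compound 4 (0.24 log units; within the scatter) and stays inside the usual scatter. This single pair shows that the place tolerates 2-(hydroxymethyl)pyrrolidin-1-yl, with its five-membered non-aromatic ring and its hydrogen-bond donor and acceptor, without a step beyond the scatter. No evidence is available that bears on this result.

On these data alone, what a plain pyrrolidin-1-yl or a morpholin-4-yl group would do at this place remains open, as does whether the hydroxymethyl group contributes anything to the step. As far as these compounds go, it is also open whether the same exchange would give a similar step with 2-methylpiperidin-1-yl or 4-(ethoxycarbonyl)piperazin-1-yl on the other double-bonded nitrogen.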